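The compounds below may be only part of what the source reports. "The series", "measured", "known", "first", "only" and "open" are said of these compounds alone.

Of the compounds shown here, three built on one shared core have been tested in a functional assay on DU-145 cells (Homo sapiens) for cytotoxicity, read by sulforhodamine B assay, with a stated time of 2 days, tested at 100 uM; on this read-out higher numbers stand for more inhibition at the one concentration tested (going by the name of the read-out) and lower numbers for less inhibition. Compound 1 `CCCc1n[nH]c2c(=O)n(NC(=O)c3ccccc3)c(-c3cccc(OC)c3)nc12` gives 23.6%, compound 3 `COc1cccc(-c2nc3c(-c4ccco4)n[nH]c3c(=O)n2NC(=O)c2ccccc2)c1` gives 50.5%, and compound 2 `COc1cccc(-c2nc3c(-c4ccc(Cl)cc4)n[nH]c3c(=O)n2NC(=O)c2ccccc2)c1` gives 94.1%, the highest of the three: its nearest neighbour is compound 3, with a number 43.6 percentage points lower from compound 2 to compound 3 (beyond the scatter), and compound 1 lies furthest, with a number 70.5 percentage points higher from compound 1 to compound 2 (beyond the scatter). Compound 4 `CCCc1nc2c(-c3ccc(Cl)cc3)n[nH]c2c(=O)n1NC(=O)c1ccccc1` differs from compound 2 in one place: propyl in place of 3-methoxyphenyl on an aromatic carbon. Going by the values given here, no measured step touches this group; the three known steps, including a number 26.9 percentage points higher from compound 1 to compound 3 (beyond the scatter), all exchange the group that is propyl in compound 1, so they show only how widely this series can swing. Among the compounds with values here, with no direct precedent, compound 4 is expected to fall by a number 34.1 percentage points lower from compound 2 to compound 4 (beyond the scatter) and is estimated at 60%, somewhere between 20% and 95%.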

Compound 4, a percentage reported as inhibition, at one concentration (the size of the read-out at that concentration, not a potency): 89.4%
Compound 4: middle estimate off by 29.4 percentage points, on the low side, within the range that was stated.
By their numbers in this assay, from the lowest: compound 1; then compound 3; then compounds 4 and 2 (each within the scatter of the next).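

In this assay, propyl in place of 3-methoxyphenyl, on the ring carbon between two ring nitrogen atoms, gives a number 4.7 percentage points lower from compound 2 to compound 4 (within the scatter). With 4-chlorophenyl held constant, this position therefore accepts a smaller group with no ring and no hydrogen-bond acceptor, and the two numbers cannot be told apart. No measured evidence explains this result.

From the compounds shown here alone, whether the same exchange behaves alike with furan-2-yl in place of 4-chlorophenyl stays open. So does the outcome for an amine, a carboxylic acid or a longer chain at this position.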